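This account rests on a few compounds, and the source may have more. Where it says the series, first, only, none or still open, it means among the compounds named here.

Measured in an ADME assay on cells (Hepatocyte, Mus musculus) for metabolic stability, with a stated time of 30 min; on this read-out higher numbers stand for a more stable compound and lower numbers for a less stable compound:
- Compound 1 `Cc1ccc(C(=O)OC2CCC(CN3CCN(c4cc(=O)c5cc(C(F)(F)F)cc([N+](=O)[O-])c5s4)CC3)CC2)cc1`: 18%
- Compound 2 `CC(=O)OC1CCC(CN2CCN(c3cc(=O)c4cc(C(F)(F)F)cc([N+](=O)[O-])c4s3)CC2)CC1`: 0%

Compound 2 holds the lower number, 0%, which leaves no room to fall. Compound 3 `O=c1cc(N2CCN(CC3CCCCC3)CC2)sc2c([N+](=O)[O-])cc(C(F)(F)F)cc12` differs from it in one place: hydrogen in place of acetoxy on a saturated ring carbon. Among the compounds with values here, only one measured step touches this group: a number 18 percentage points lower from compound 1 to compound 2 (beyond the scatter). That step alters the group but does not remove it, so it is only a loose guide. A modest rise in this assay is expected, with much uncertainty. The expected change is a number 15 percentage points higher from compound 2 to compound 3 (beyond the scatter). The estimate for compound 3 is 15%, with an expected range of 0% to 40%.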

Compound 3, percent of the compound remaining: 80.6%
Estimate against measurement, compound 3: 65.6 percentage points below; the measured number lies above the stated range.
By their numbers in this assay, from the lowest: compound 2; then compound 1; then compound 3.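

In this assay, hydrogen in place of acetoxy on this saturated ring carbon gives a number 80.6 percentage points higher from compound 2 to compound 3 (beyond the scatter) and hydrogen in place of ((4-methylphenyl)carbonyl)oxy gives a number 62.6 percentage points higher from compound 1 to compound 3 (beyond the scatter). Both steps are large, so the bare cyclohexylmethyl compound stands well clear of both esters, a gap that the step between the two esters did not reveal. Nothing available explains this rise.

Going by these compounds, it remains open whether any group on this carbon would lower the number or only an ester would. A hydroxyl, an amine or a methyl ether there would help to separate those two readings.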